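From Fluoro to Tert-Butyl on the Fused Ring

The source may hold more compounds than are shown below. What is called first, only, known or untested is meant among the compounds shown, and "the series" means these compounds.

Compound 3 `CN1CCC(NC(=O)Nc2cccc3[nH]ncc23)c2ccc(F)cc21` shares its urea core with compound 1 `O=C(Nc1cccc2[nH]ncc12)NC1CCOc2c(OC(F)(F)F)cccc21` and compound 2 `CN1CCC(NC(=O)Nc2cccc3[nH]ncc23)c2ccccc21`. In a functional assay for antagonist activity at transient receptor potential cation channel subfamily V member 1 (Homo sapiens), read by calcium flux (a higher number here means a weaker inhibitor, a lower number a stronger inhibitor), compound 1 gives 5 nM, compound 2 gives 215 nM and compound 3 gives 34 nM, so compound 3 stands second highest of the three, between the two others. Going by the values given here, the single step that bears on the change ahead, a 6.3-fold lower number from compound 2 to compound 3 (0.80 log units; beyond the scatter), shows that a substituent at this aromatic carbon can shift the number. Among the compounds with values here, compound 4 `CN1CCC(NC(=O)Nc2cccc3[nH]ncc23)c2ccc(C(C)(C)C)cc21` carries tert-butyl in place of fluoro on an aromatic carbon; no measured step tells what a larger group does at that place. Compound 4 in this assay is therefore expected to show only a small step, a 1.4-fold lower number from compound 3 to compound 4 (0.13 log units; within the scatter), not beyond the usual scatter. Compound 4 is estimated at 25 nM, between 6 nM and 120 nM.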

Compound 4, half-maximal inhibitory concentration: 115 nM
For compound 4 the middle estimate is 4.6-fold (0.66 log units) below the measured one, and the stated range covers the measured number.
By their numbers in this assay, from the lowest: compound 1; then compound 3; then compounds 4 and 2 (each within the scatter of the next).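

In this assay, the gain seen with fluoro at this aromatic carbon does not carry over to a larger group: tert-butyl in place of fluoro gives a 3.4-fold higher number from compound 3 to compound 4 (0.53 log units; beyond the scatter). Tert-butyl in place of hydrogen leaves the number within the scatter, with a 1.9-fold lower number from compound 2 to compound 4 (0.27 log units; within the scatter), so at this place the outcome depends on which group is attached. No measurement here accounts for this difference.

As far as these compounds go, whether chloro, methyl or methoxy at this place would read closer to compound 3 or to compound 4 remains open.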